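Swapping a Piperidine Amide for a Methylbenzyl Group

The source may hold more compounds than are shown below. What is called first, only, known or untested is meant among the compounds shown, and "the series" means these compounds.

Compound 1, `COc1cc(OC)c(-c2nc3cc(/C=C4\SC(=O)NC4=O)ccc3[nH]2)cc1OC`, gives 1840 nM in a functional assay on A549 cells (Homo sapiens) for inhibition, read by MTT assay, with a stated time of 48 h; on this read-out higher numbers stand for weaker inhibition and lower numbers for stronger inhibition.
Compound 2, `COc1cc(OC)c(-c2nc3cc(/C=C4\SC(=O)N(CC(=O)N5CCCCC5)C4=O)ccc3[nH]2)cc1OC`, gives 14500 nM in this assay.
Compound 3, `COc1cc(OC)c(-c2nc3cc(/C=C4\SC(=O)N(Cc5cccc(C)c5)C4=O)ccc3[nH]2)cc1OC`, is not yet measured.

Among the measured compounds shown here, compound 2 has the highest of the two numbers so far; its nearest neighbour is compound 1, and the step of a 7.9-fold higher number from compound 1 to compound 2 (0.90 log units; beyond the scatter) separates them. The move to compound 3 is 3-methylphenyl in place of (piperidin-1-yl)carbonyl on a saturated chain carbon bound to an amide-type nitrogen in a ring. For the measured compounds named here, the only measured step that touches this position is a 7.9-fold higher number from compound 1 to compound 2 (0.90 log units; beyond the scatter), and it shows that replacing the hydrogen on the ring nitrogen with a chain carrying the piperidine amide weakened inhibition. Going by the values given here, compound 3 keeps a chain on that nitrogen but exchanges the piperidine amide for a methylphenyl ring, and no measured pair compares two different groups at this position, so the direction of the change rests on judgement alone. Compound 3 is expected to land between its two relatives, with an estimated step of a 2.4-fold lower number from compound 2 to compound 3 (0.38 log units; beyond the scatter). The estimate for compound 3 is therefore 6000 nM, within a range from 1500 nM to 25000 nM.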

Compound 3, half-maximal inhibitory concentration: 130 nM
The estimate for compound 3 lay 46-fold (1.66 log units) above the measured number; the whole stated range lies above it.
By their numbers in this assay, from the lowest: compound 3; then compound 1; then compound 2.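

Exchanging (piperidin-1-yl)carbonyl for 3-methylphenyl on the saturated chain carbon gives a 110-fold lower number from compound 2 to compound 3 (2.05 log units; beyond the scatter) in this assay, so what the chain carries counts for far more here than the presence of a chain alone. Putting a group on the amide-type nitrogen in the ring can also strengthen inhibition, not only weaken it: in place of the hydrogen, 3-methylbenzyl gives a 14-fold lower number from compound 1 to compound 3 (1.15 log units; beyond the scatter), while the earlier step, a 7.9-fold higher number from compound 1 to compound 2 (0.90 log units; beyond the scatter), ran the other way. Nothing measured here explains why these two groups differ so widely.

The compounds shown cannot separate the part played by the methyl from the part played by the aromatic ring, and an unsubstituted benzyl group on the same nitrogen would be the direct test of that. Going by these compounds, how far the chain itself can change also stays open, whether as a longer chain such as 2-phenylethyl or as a chain ending in an amine or a carboxylic acid.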